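Rat Agonist Dose: A Ring Rearranged, Chain Shortened

This account rests on a few compounds, and the source may have more. Where it says the series, first, only, none or still open, it means among the compounds named here.

Measured so far:
- compound 1 `c1ccc2c(c1)CC2CCCCN1CCN(c2cccc3c2OCCO3)CC1`: > 10 mg/kg (a limit)
- compound 2 `c1ccc2c(c1)CC2CCCN1CCN(c2cccc3c2OCCO3)CC1`: 10 mg/kg
- compound 3 `Clc1cccc2c1CC2CCCN1CCN(c2cccc3c2OCCO3)CC1`: > 10 mg/kg (a limit)

Of the compounds shown here, three have been tested in a functional assay on the whole organism for agonist activity, with Rattus norvegicus as the target; on this read-out lower numbers stand for an effect already at smaller amounts and higher numbers for an effect only at larger amounts of compound. Compound 2 is the only one that gives an actual number, 10 mg/kg. Compound 1 reached only the limit of the assay, > 10 mg/kg. Compound 3 likewise reached only a limit, > 10 mg/kg. Because of the limit of > 10 mg/kg in this assay, at which 2 of the 3 values shown sit, the measured steps cannot be read as sizes: a number no higher from compound 1 to compound 2 (the limit leaves the size open), a number no lower from compound 2 to compound 3 (the limit leaves the size open), and a step that the two limits leave unreadable from compound 1 to compound 3.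

Compound 4 `c1ccc2c(c1)CCC2CCN1CCN(c2cccc3c2OCCO3)CC1` has not been measured. It differs from compound 2 in this way: a group of 9 heavy atoms (9 carbon; one five-membered non-aromatic ring of carbon only, one six-membered aromatic ring of carbon only) in place of a group of 9 heavy atoms (9 carbon; one four-membered non-aromatic ring of carbon only, one six-membered aromatic ring of carbon only), on a saturated chain carbon, two bonds along the chain from an amine nitrogen in a ring. The measured steps concern a change on a saturated chain carbon three bonds along the chain from an amine nitrogen in a ring, while the step to compound 4 alters the ring size and the place on the chain, so none of them speaks directly to it. Going by the values given here, with no step of readable size to lean on, the expectation for compound 4 in this assay is simply a number near that of compound 2, and the step of no change at the digits printed from compound 2 to compound 4 (within the scatter) is estimated to lie within the scatter. Compound 4 is therefore expected to give about 10 mg/kg, between 3 mg/kg and 30 mg/kg, with a real chance that only a limit is reported.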

Compound 4, minimum effective dose: > 40 mg/kg
Compound 4 was reported as a limit; the forecaster's own chance of this, stated with the estimate: 50%; middle value at least 4.0-fold (0.60 log units) from the limit.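

Going by these compounds alone, the earlier steps cannot be read as sizes, and this is the first one that can be. Putting 2,3-dihydro-1H-inden-1-yl in place of the group of compound 2 with its four-membered ring, on a saturated chain carbon, two bonds along the chain from an amine nitrogen in a ring, gives an at least 4.0-fold higher number from compound 2 to compound 4 (0.60 log units; beyond the scatter) in this assay. The two compounds hold the same atoms, joined differently, which shows that rearranging the atoms of this part alone, with none gained or lost, can push the effect out to larger amounts of compound. How far the step really reaches stays open because the value for compound 4 is a limit and not a number: the limit of > 40 mg/kg in this assay, at which 1 of the 4 values shown sits.

This one step changes the ring and the chain together, and the compounds shown leave open which of the two accounts for it. Also open, from the compounds shown here alone, is how the 2,3-dihydro-1H-inden-1-yl group would read on a longer chain, or with a chloro or an amine on its aromatic ring.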